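Methoxy to fluoro on compound 1

A few compounds are considered here, and "the series" means these few. Any claim that something is new, unique, unknown or untested is made for them only; others in the source may bear on it.

Among the measured compounds shown here, in a functional assay on SGC-7901 cells (Homo sapiens) for cytotoxicity, read by MTT assay, with a stated time of 48 h (on this read-out higher numbers stand for weaker inhibition and lower numbers for stronger inhibition), compound 1 (`COc1ccc(-c2nnc(SCCn3c([N+](=O)[O-])cnc3C)o2)cc1`) gives 10200 nM, the lowest of the three numbers measured so far and the strongest inhibition in the set. Compound 2 (`CCOc1ccccc1-c1nnc(SCCn2c([N+](=O)[O-])cnc2C)o1`) gives 30300 nM and compound 3 (`Cc1ncc([N+](=O)[O-])n1CCSc1nnc(-c2ccccc2[N+](=O)[O-])o1`) gives 30000 nM. Both of these numbers lie higher than that of compound 1, beyond the scatter.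

Compound 4 (`Cc1ncc([N+](=O)[O-])n1CCSc1nnc(-c2ccc(F)cc2)o1`) keeps the core of compound 1 and changes one group: fluoro in place of methoxy on an aromatic carbon. This is fluoro in place of methoxy on an aromatic carbon, para to a large group.

For the measured compounds named here, only one measured step bears on this change: a 1.0-fold lower number from compound 2 to compound 3 (0.00 log units; within the scatter), where nitro replaces ethoxy on an aromatic carbon. Going by the values given here, it involves other groups, and no measured compound carries fluoro, so it gives weak guidance, though it offers no sign of a large step. Compound 1 at 10200 nM sits at the low end of the series, so a move towards a higher number is expected to be more likely than a move towards a lower one. The expected step is modest: a 1.6-fold higher number from compound 1 to compound 4 (0.20 log units; within the scatter). For compound 4 the estimated value in this assay is 16000 nM, with an expected range of 6000 nM to 40000 nM.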

Compound 4, half-maximal inhibitory concentration: 5300 nM
Estimate against measurement, compound 4: 3.0-fold (0.48 log units) above; the whole stated range lies above it.
By their numbers in this assay, from the lowest: compounds 4 and 1 (each within the scatter of the next); then compounds 3 and 2 (each within the scatter of the next).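

In this assay, among the compounds shown here, the first change at this place, on an aromatic carbon para to a large group, gives a 1.9-fold lower number from compound 1 to compound 4 (0.28 log units; within the scatter) and so does not separate the two compounds; the only earlier step, a 1.0-fold lower number from compound 2 to compound 3 (0.00 log units; within the scatter), involved other groups and could not speak to this position. Within this single pair, 4-methoxyphenyl and 4-fluorophenyl give numbers that cannot be told apart, even though the exchange removes one heavy atom and the one hydrogen-bond acceptor of the methoxy group, so neither that oxygen nor that carbon is shown to be required for the read-out at this level of resolution. No measurement here accounts for this outcome or links it to any property of either group, and the step therefore stands as an observation only.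

The compounds shown leave open whether any group at this place gives a step beyond the scatter, for instance an amine, a carboxylic acid or a longer alkoxy chain such as butoxy. They also leave open whether fluoro in place of methoxy reads the same way on a core other than the core of compound 1 .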